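From a Propyl Chain to a Branched Alkyl Group

The compounds below may be only part of what the source reports. "The series", "measured", "known", "first", "only" and "open" are said of these compounds alone.

Compound 3 `CCCN(CCC)c1nc(-c2ccc(Cl)cc2OC)n(C)n1` stands at the edge of what an in vitro assay on Ltk- cells for binding affinity to corticotropin-releasing factor receptor 1 (Homo sapiens) (on this read-out lower numbers stand for stronger inhibition and higher numbers for weaker inhibition), can report: in this assay compound 3 gives > 10000 nM, which is a limit (the limit of > 10000 nM in this assay, at which 1 of the 3 values shown sits). Compound 1 `CCCN(CC1CC1)c1nc(-c2ccc(Cl)cc2OC)n(C)n1` gives 2600 nM and compound 2 `CCCN(c1nc(-c2ccc(Cl)cc2OC)n(C)n1)C(CC)c1ccccc1` gives 26 nM. Compound 4 `CCCN(c1nc(-c2ccc(Cl)cc2OC)n(C)n1)C(C(C)C)C(C)C` differs from compound 3 by 1-isopropyl-2-methylpropyl in place of propyl on a nitrogen on an aromatic ring. Going by the values given here, two measured steps bear on this change. an at least 380-fold higher number from compound 2 to compound 3 (2.58 log units; beyond the scatter) shows that stripping a group from the chain carbon bound to the nitrogen weakens binding greatly, and an at least 3.8-fold higher number from compound 1 to compound 3 (0.58 log units; beyond the scatter) points the same way on a smaller scale. Compound 4 restores branching at that carbon, so compound 4 is expected to show an at least 66-fold lower number from compound 3 to compound 4 (1.82 log units; beyond the scatter). Compound 4 is estimated at 150 nM, with a range from 25 nM to 1500 nM.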

Compound 4, inhibition constant: 910 nM
Compound 4: middle estimate off by 6.1-fold (0.78 log units), on the low side; the range from low to high includes it.
By their numbers in this assay, from the lowest: compound 2; then compound 4; then compound 1. At a limit, above all of these: compound 3.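

Alkyl branching alone, with no ring in the entering group, lowers the number in this assay (an at least 10-fold lower number from compound 3 to compound 4 (1.04 log units; beyond the scatter)), and the size of that step is only a bound, since compound 3 sits at a limit: the limit of > 10000 nM in this assay, at which 1 of the 4 values shown sits.
The 1-isopropyl-2-methylpropyl group also does modestly better than cyclopropylmethyl (a 2.9-fold lower number from compound 1 to compound 4 (0.46 log units; beyond the scatter)), but falls far short of 1-phenylpropyl (a 35-fold higher number from compound 2 to compound 4 (1.54 log units; beyond the scatter)).
Branching alone therefore does not match the group that carries phenyl. On these data alone, whether that edge needs an aromatic ring stays open, and a 1-cyclohexylpropyl group in the same place would test this.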